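Notes on the step from compound 3 to compound 4

A few compounds are considered here, and "the series" means these few. Any claim that something is new, unique, unknown or untested is made for them only; others in the source may bear on it.

Compound 1 `C/C(C(N)=O)=C(/C)c1ccc(Cl)cc1` gives 20.9 mg/kg in a functional assay on the whole organism with Mus musculus as the target; on this read-out lower numbers stand for an effect already at smaller amounts and higher numbers for an effect only at larger amounts of compound. Compound 2 `C/C(C(=O)NC1CC1)=C(/C)c1ccc(Cl)cc1` gives 11.4 mg/kg in this assay, and compound 3 `C=CCNC(=O)/C(C)=C(\C)c1ccc(Cl)cc1` gives 18.6 mg/kg. Compound 3 thus sits second highest of the three numbers, although every pairwise step stays within the scatter: a 1.1-fold lower number from compound 1 to compound 3 (0.05 log units; within the scatter), a 1.6-fold higher number from compound 2 to compound 3 (0.21 log units; within the scatter) and a 1.8-fold lower number from compound 1 to compound 2 (0.26 log units; within the scatter). All three measured steps alter only the substituent on the amide-type nitrogen. Compound 4 `C=CCNC(=O)/C(C)=C(\C)c1ccccc1` differs from compound 3 by hydrogen in place of chloro on an aromatic carbon. Among the compounds with values here, no measured step touches the aromatic ring, so nothing bears directly on this change; the expectation is therefore no step beyond the scatter, a 1.2-fold higher number from compound 3 to compound 4 (0.07 log units; within the scatter), with wide uncertainty. Compound 4 is estimated at 22 mg/kg, within 8 mg/kg to 60 mg/kg.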

Compound 4, dose for half-maximal effect: 67 mg/kg
Compound 4: middle estimate off by 3.0-fold (0.48 log units), on the low side; the whole stated range lies below it.
By their numbers in this assay, from the lowest: compounds 2, 3 and 1 (each within the scatter of the next); then compound 4.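

In this assay, within the data shown here, replacing the chloro on the aromatic carbon, para to a large group, with hydrogen gives the only step so far beyond the scatter (a 3.6-fold higher number from compound 3 to compound 4 (0.56 log units; beyond the scatter)). The steps on the amide-type nitrogen all stay within the scatter, so this ring position shows a difference that those substituents did not. Nothing measured here accounts for this step.

Open, going by these compounds, is whether fluoro, bromo, methyl or methoxy at this position would give a number like that of compound 3. Also open, on these data alone, is whether the same exchange would give a similar step with cyclopropyl on the nitrogen.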